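The source may report more compounds than this note shows. Statements on the series, on what has been measured and on what is new or still open speak of the compounds shown alone.

Within the data shown here, compound 2 `O=C(O)CN1C(=O)/C(=C/c2nc3ccccc3n2Cc2ccc(Br)cc2F)SC1=S` stands highest of the three numbers so far: in a functional assay on PC-3 cells (Homo sapiens) for cytotoxicity, read by MTT assay, with a stated time of 48 h (a higher number here means a weaker inhibitor, a lower number a stronger inhibitor), compound 2 gives 21100 nM. Compound 1 `O=C(O)CN1C(=O)/C(=C/c2nc3ccccc3n2Cc2ccc(Br)cc2)SC1=S` gives 8490 nM in this assay, and compound 3 `O=C(O)CN1C(=O)/C(=C/c2nc3ccccc3n2Cc2ccc([N+](=O)[O-])cc2)SC1=S` gives 8270 nM. Compound 4 `O=C(O)CN1C(=O)/C(=C/c2nc3ccccc3n2Cc2ccc(F)cc2)SC1=S` differs from compound 2 by 4-fluorophenyl in place of 4-bromo-2-fluorophenyl on a saturated chain carbon bound to an aromatic nitrogen. Among the measured compounds shown here, two measured steps bear on this. The step of a 2.5-fold higher number from compound 1 to compound 2 (0.40 log units; beyond the scatter) shows that the fluoro in place of hydrogen raised the number, and compound 4 undoes that fluoro. The step of a 1.0-fold lower number from compound 1 to compound 3 (0.01 log units; within the scatter) shows that exchanging the bromo left the number within the scatter, so the bromo-to-fluoro exchange is expected to matter little. The number for compound 4 is therefore expected to fall back toward compound 1, an estimated 2.3-fold lower number from compound 2 to compound 4 (0.37 log units; beyond the scatter). Compound 4 is estimated at 9000 nM, within 4000 nM to 20000 nM.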

Compound 4, half-maximal inhibitory concentration: 4860 nM
For compound 4 the middle estimate is 1.9-fold (0.27 log units) above the measured one; measured number inside the range.
By their numbers in this assay, from the lowest: compounds 4, 3 and 1 (each within the scatter of the next); then compound 2.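

In this assay, the change from 4-bromo-2-fluorobenzyl to 4-fluorobenzyl gives a 4.3-fold lower number from compound 2 to compound 4 (0.64 log units; beyond the scatter), so a fluoro on the benzyl ring does not by itself bring the high number of compound 2. With one group on that ring, bromo, nitro and fluoro are not told apart: a 1.7-fold lower number from compound 1 to compound 4 (0.24 log units; within the scatter) and a 1.7-fold lower number from compound 3 to compound 4 (0.23 log units; within the scatter) both stay within the scatter. Compound 2, which carries both bromo and fluoro, goes against this pattern. Nothing measured here gives a reason for these numbers. As far as these compounds go, it remains open whether an amine on that ring, or a longer chain in place of the benzyl group, would keep the number in this range.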